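Methoxycarbonyl to carboxy: from compound 1 to compound 4

The compounds below may be only part of what the source reports. "The series", "measured", "known", "first", "only" and "open" are said of these compounds alone.

In a functional assay on DU-145 cells (Homo sapiens) for inhibition, read by MTT assay, with a stated time of 72 h (a lower number here means a stronger inhibitor, a higher number a weaker inhibitor), compound 1 `COC(=O)CCCCCCC(=O)Nc1cccc(OS(=O)(=O)C2CC3OC2C(c2ccc(O)cc2)=C3c2ccc(O)cc2)c1` gives 19300 nM and lies within the scatter of compound 3 `O=C(CCCCCCC(=O)Nc1ccc(C2=C(c3ccc(O)cc3)C3CC(S(=O)(=O)Oc4ccc(Br)cc4)C2O3)cc1)NO` at 11300 nM in this set. Compound 2 `O=C(O)CCCCCCC(=O)Nc1ccc(C2=C(c3ccc(O)cc3)C3CC(S(=O)(=O)Oc4ccc(C(F)(F)F)cc4)C2O3)cc1` at 77000 nM is weaker than compound 1 by more than the scatter. Compound 4 `O=C(O)CCCCCCC(=O)Nc1cccc(OS(=O)(=O)C2CC3OC2C(c2ccc(O)cc2)=C3c2ccc(O)cc2)c1` has hydrogen in place of methyl on an oxygen next to a carbonyl group, which is methoxycarbonyl to carboxy. For the measured compounds named here, no measured pair shows this change alone. Compound 2 also carries carboxy, though it differs elsewhere too, and its 77000 nM points towards weakening. The expected step (a 2.6-fold higher number from compound 1 to compound 4 (0.41 log units; beyond the scatter)) is a loss of inhibition beyond the scatter. The estimated value for compound 4 is 50000 nM in this assay with an expected range from 20000 nM to 120000 nM around it.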

Compound 4, half-maximal inhibitory concentration: > 100000 nM
Compound 4: a limit, no number; the forecaster's own chance of this, stated with the estimate: 15%; at least 2.0-fold (0.30 log units) between middle value and limit.
By their numbers in this assay, from the lowest: compounds 3 and 1 (each within the scatter of the next); then compound 2. At a limit, above all of these: compound 4.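

Compound 4 reaches only a limit in this assay, not a number: the limit of > 100000 nM in this assay, at which 1 of the 4 values shown sits. For the compounds shown here, this gives the first direct reading of methoxycarbonyl to carboxy on this scaffold, with all else held the same, and the change weakens inhibition: an at least 5.1-fold higher number from compound 1 to compound 4 (0.71 log units; beyond the scatter). On these data alone, that step is a minimum, so the full size of the loss remains unknown. As far as these compounds go, whether an ethyl ester or a primary amide in this place would keep the inhibition of compound 1 stays open. So does whether a shorter chain would alter the effect of the carboxy group.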